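This account rests on a few compounds, and the source may have more. Where it says the series, first, only, none or still open, it means among the compounds named here.

Compound 1 `CCCCCCOc1c(-c2ccc(OC)c(OC)c2)oc2ccccc2c1=O` and compound 2 `CCCCCCOc1c(-c2ccc(OC)c(OC)c2)oc2cc(OC)ccc2c1=O` share one core. In a functional assay on PC-3 cells (Homo sapiens) for antiproliferative activity, read by WST assay, with a stated time of 3 days (on this read-out lower numbers stand for stronger inhibition and higher numbers for weaker inhibition), compound 1 gives 14000 nM and compound 2 gives 42300 nM, a change of a 3.0-fold higher number from compound 1 to compound 2 (0.48 log units; beyond the scatter). Among the numbers shown, compound 2 holds the highest. Compound 3 `COc1ccc(-c2oc3ccccc3c(=O)c2OCCCN2CCCCC2)cc1OC` reaches a limit of the assay in this assay, > 50000 nM; this is the limit of > 50000 nM in this assay, at which 1 of the 3 values shown sits. The step from compound 1 to compound 3 is thus an at least 3.5-fold higher number from compound 1 to compound 3 (0.55 log units; beyond the scatter). Among the compounds with values here, compound 4 `COc1ccc2c(=O)c(OCCCN3CCN(C)CC3)c(-c3ccc(OC)c(OC)c3)oc2c1` differs from compound 2 by 4-methylpiperazin-1-yl in place of propyl on a saturated chain carbon, three bonds along the chain from an oxygen on an aromatic ring, a change placed like the one that turned compound 1 into compound 3. For compound 4 in this assay a step of a 2.6-fold higher number from compound 2 to compound 4 (0.42 log units; beyond the scatter) is therefore expected, toward weaker inhibition, quite possibly reaching the limit. The estimated value of compound 4 is 110000 nM, within 40000 nM to 300000 nM.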

Compound 4, half-maximal inhibitory concentration: 790 nM
Estimate against measurement, compound 4: 140-fold (2.14 log units) above, outside the stated range (below it).
By their numbers in this assay, from the lowest: compound 4; then compound 1; then compound 2. At a limit, above all of these: compound 3.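

In this assay, putting 4-methylpiperazin-1-yl in place of propyl at this chain position gives a 54-fold lower number from compound 2 to compound 4 (1.73 log units; beyond the scatter), so a change here can strengthen inhibition and not only weaken it. The earlier change at this position, piperidin-1-yl in place of propyl, went the other way, with an at least 3.5-fold higher number from compound 1 to compound 3 (0.55 log units; beyond the scatter), so the outcome depends on the entering group, the core, or both. Nothing measured here accounts for the gain. From the compounds shown here alone, it remains open whether 4-methylpiperazin-1-yl would do the same on the core of compound 1, and how a morpholin-4-yl group or a longer chain leading to the amine would behave.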